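The source may hold more compounds than are shown below. What is called first, only, known or untested is meant among the compounds shown, and "the series" means these compounds.

Compound 1 `CCCc1ccc2[nH]c(-c3ccccc3)c(C3=C(Br)C(=O)NC3=O)c2c1` and compound 2 `CCCCc1ccc2[nH]c(-c3ccccc3)c(C3=C(Br)C(=O)NC3=O)c2c1` share one core and differ in a single place: methyl in place of hydrogen on a saturated chain carbon, three bonds along the chain from an aromatic carbon. In a physicochemical assay for lipophilicity (on this read-out higher numbers stand for higher lipophilicity and lower numbers for lower lipophilicity), compound 1 gives 3.43, while compound 2 gives 3.74, so that a number 0.31 log units higher from compound 1 to compound 2 (beyond the scatter). Compound 3 `CCCCc1ccc2[nH]c(-c3ccc(OC)cc3)c(C3=C(Br)C(=O)NC3=O)c2c1` differs from compound 2 by a methoxy in place of hydrogen on an aromatic carbon; in this assay compound 3 gives 3.83, and a number 0.09 log units higher from compound 2 to compound 3 (within the scatter). The difference between the cores of compound 1 and compound 3 is not broken down here. Compound 4 `CCCCCc1ccc2[nH]c(-c3ccc(OC)cc3)c(C3=C(Br)C(=O)NC3=O)c2c1` differs from compound 3 by methyl in place of hydrogen on a saturated chain carbon, four bonds along the chain from an aromatic carbon. This is the same kind of change as that from compound 1 to compound 2, but it sits four bonds along the chain from an aromatic carbon rather than three. A similar step is expected, a number 0.30 log units higher from compound 3 to compound 4 (within the scatter), because the earlier comparison gave a number 0.31 log units higher from compound 1 to compound 2 (beyond the scatter). Compound 4 is therefore estimated to give 4.13, with a likely range from 3.85 to 4.45.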

Compound 4, partition coefficient: 4.1
Estimate against measurement, compound 4: 0.03 log units above, and the stated range covers the measured number.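

In this assay the same methyl change on the core of compound 3 gives a number 0.27 log units higher from compound 3 to compound 4 (within the scatter) while the earlier step on another core gave a number 0.31 log units higher from compound 1 to compound 2 (beyond the scatter). The two steps are close in size, which suggests that the change carries over between these two cores, although the new step alone stays within the usual scatter. Among the compounds shown here, this is only one pair of steps, taken at two places along the chain, so it does not show that the change would behave alike on other cores.

No measurement shown here explains the size of either step. From the compounds shown here alone, it remains open whether a longer chain such as hexyl, or an amine or a carboxylic acid in place of the added methyl, would follow the same trend.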